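The source may report more compounds than this note shows. Statements on the series, on what has been measured and on what is new or still open speak of the compounds shown alone.

Measured so far:
compound 1 `COc1ccccc1NC(=O)N[C@H](C)c1ccccc1`: 96%
compound 2 `C[C@@H](NC(=O)Nc1ccccc1Cl)c1ccccc1`: 93%

Both compounds share the same core and differ only at one aromatic carbon. In an ADME assay on the whole organism with Oryza sativa as the target, tested at 10 uM (on this read-out higher numbers stand for a weaker effect at the one concentration tested and lower numbers for a stronger effect), compound 1 gives 96%, and in the same assay compound 2 gives 93%. For the measured compounds named here, the single measured step, a number 3 percentage points lower from compound 1 to compound 2 (within the scatter), brought chloro in place of methoxy on an aromatic carbon and did not move the read-out beyond the scatter, so compound 2 stands beside compound 1 with no separation that can be trusted.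

Compound 3 `C[C@@H](NC(=O)Nc1c(Cl)cccc1Cl)c1ccccc1` is the next compound in this series. It differs from compound 2 by chloro in place of hydrogen on an aromatic carbon. Going by the values given here, no measured step adds a chloro in place of hydrogen; the only step available, a number 3 percentage points lower from compound 1 to compound 2 (within the scatter), concerns a different exchange at the same kind of position and was itself within the scatter. Among the compounds with values here, with that as the sole guide, no step beyond the scatter is expected in this assay in either direction. Compound 3 is therefore expected to give about 92%, in a range from 80% to 100%. The expected step is a number 1 percentage points lower from compound 2 to compound 3 (within the scatter), within the scatter.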

Compound 3, a percentage reported as activity, at one concentration (the size of the read-out at that concentration, not a potency): 100%
Beside the measured number, compound 3's estimate is 8 percentage points below it; low and high end bracket the measured number.
By their numbers in this assay, from the lowest: compounds 2, 1 and 3 (each within the scatter of the next).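

In this assay, chloro in place of hydrogen on an aromatic carbon, ortho to a large group and meta to a chloro group, gives a number 7 percentage points higher from compound 2 to compound 3 (within the scatter). The other measured step exchanged one group for another, whereas this one adds a group at a carbon that held only hydrogen, and it shows that a second chloro on this ring brings no separation that can be trusted. Nothing measured speaks to what lies behind this result.

The three compounds carry only methoxy or chloro on this ring and their numbers lie within the scatter of one another, so they leave open whether a different group here, such as an amine, a carboxylic acid or a longer chain, would move the read-out in this assay beyond the scatter. They also leave open whether any change elsewhere on the shared core would separate compounds on this read-out.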